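From a Bromophenyl to a Nitrophenyl Arm

A few compounds are considered here, and "the series" means these few. Any claim that something is new, unique, unknown or untested is made for them only; others in the source may bear on it.

Compound 3 `N/C(=N/NC(CC(=O)c1ccc(-n2ccnc2)cc1)c1cccc(Br)c1)c1ccccn1` gives 51300 nM in an ADME assay on Vero cells (Chlorocebus sabaeus) for cytotoxicity, read by MTT assay, with a stated time of 72 h (a lower number here means that less compound is tolerated, a higher number that more compound is tolerated), the second highest of the three numbers in hand. Compound 1 `N/C(=N/NC(CC(=O)c1ccc(-n2ccnc2)cc1)c1ccc(F)cc1)c1ccccn1` gives 78800 nM, and compound 2 `N/C(=N/NC(CC(=O)c1ccc(-n2ccnc2)cc1)c1cccc(F)c1)c1ccccn1` gives 26500 nM. Compound 4 `N/C(=N/NC(CC(=O)c1ccc(-n2ccnc2)cc1)c1ccc([N+](=O)[O-])cc1)c1ccccn1` has not yet been tested; it differs by 4-nitrophenyl in place of 3-bromophenyl on a saturated chain carbon bound to an amine nitrogen and a saturated chain carbon. Within the data shown here, no measured step introduces a nitro group, so only the steps that move or swap a halogen can guide: a 1.5-fold lower number from compound 1 to compound 3 (0.19 log units; within the scatter), while a 3.0-fold lower number from compound 1 to compound 2 (0.47 log units; beyond the scatter) and a 1.9-fold higher number from compound 2 to compound 3 (0.29 log units; within the scatter). Compound 1 and compound 3 sit within the scatter of each other. Compound 4 is therefore expected to show a 1.2-fold higher number from compound 3 to compound 4 (0.07 log units; within the scatter), most likely nothing beyond the scatter. Compound 4 is estimated at 60000 nM, within a range of 25000 nM to 150000 nM.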

Compound 4, half-maximal cytotoxic concentration: 23100 nM
Compound 4: the middle estimate sits 2.6-fold (0.41 log units) above what was measured, outside the stated range (below it).
By their numbers in this assay, from the lowest: compounds 4, 2, 3 and 1 (each within the scatter of the next, the first and the last beyond it).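

Nitro in place of fluoro is the first change here to carry a compound well away from the bromo analogue in this assay, with a 2.2-fold lower number from compound 3 to compound 4 (0.35 log units; beyond the scatter) and, against the fluoro parent, a 3.4-fold lower number from compound 1 to compound 4 (0.53 log units; beyond the scatter) beyond the scatter as well. With a 1.1-fold lower number from compound 2 to compound 4 (0.06 log units; within the scatter) inside the scatter, the 4-nitrophenyl and 3-fluorophenyl arms cannot be told apart. Placement alone therefore does not settle the outcome at this saturated chain carbon.

Nothing available explains these shifts. From the compounds shown here alone, whether an amine or a carboxylic acid on this phenyl ring would follow the nitro compound remains open.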